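Swapping an Ether Chain for a Hydroxyethyl Amide

The source may report more compounds than this note shows. Statements on the series, on what has been measured and on what is new or still open speak of the compounds shown alone.

Three compounds share one core. Compound 1 `CC(=O)NCC[C@@H]1C[C@@H](c2ccc(F)c(F)c2)[C@H](NC(=O)c2cc(-c3c(Cl)cnn3C)c(Cl)o2)CN1` gives 2.49 nM in an assay for inhibition of RAC-alpha serine/threonine-protein kinase (Homo sapiens), read by HTRF, with a stated time of 1 h; on this read-out higher numbers stand for weaker inhibition and lower numbers for stronger inhibition. Compound 2 `Cn1ncc(Cl)c1-c1cc(C(=O)NC2CNCC2c2ccc(C(F)(F)F)cc2)oc1Cl` gives 538 nM in this assay, the highest number of the three. Compound 3 `COCC[C@@H]1C[C@@H](c2ccc(Cl)c(Cl)c2)[C@H](NC(=O)c2cc(-c3c(Cl)cnn3C)c(Cl)o2)CN1` gives 7.01 nM, the second highest of these three numbers; compound 1 stands nearest and compound 2 furthest, both beyond the usual scatter. Compound 4 `Cn1ncc(Cl)c1-c1cc(C(=O)N[C@@H]2CN[C@H](CC(=O)NCCO)C[C@H]2c2ccc(Cl)c(Cl)c2)oc1Cl` differs from compound 3 in one place: (2-hydroxyethyl)carbamoyl in place of methoxymethyl on a saturated chain carbon bound to a saturated ring carbon. Compound 1 also carries an amide in its chain and gives 2.49 nM, so compound 4 is estimated at 5 nM in this assay, with a range from 1.5 nM to 15 nM. The expected step of a 1.4-fold lower number from compound 3 to compound 4 (0.15 log units; within the scatter) is small, toward slightly stronger inhibition, and within the usual scatter.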

Compound 4, half-maximal inhibitory concentration: 1.41 nM
For compound 4 the middle estimate is 3.5-fold (0.55 log units) above the measured one; measured number below the stated range.
By their numbers in this assay, from the lowest: compounds 4 and 1 (each within the scatter of the next); then compound 3; then compound 2.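

On the saturated chain carbon bound to a saturated ring carbon, (2-hydroxyethyl)carbamoyl in place of methoxymethyl gives a 5.0-fold lower number from compound 3 to compound 4 (0.70 log units; beyond the scatter) in this assay. This single change shows that the position accepts a larger group carrying an amide and a hydroxyl with a gain, not a loss, in inhibition. Nothing available explains the gain.

Which part of the entering group accounts for the step remains open. A methylcarbamoyl group, or a chain ending in an amine or a carboxylic acid, at this place would bear on that question.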